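A few compounds are considered here, and "the series" means these few. Any claim that something is new, unique, unknown or untested is made for them only; others in the source may bear on it.

Compound 1 `CCOc1cc(C(Nc2ccc3c(N)nccc3c2)C(=O)NS(=O)(=O)c2cccc(C(N)=O)c2)ccc1OC(C)C` gives in an assay on isolated protein for inhibition of Trypsin (Homo sapiens) (on this read-out higher numbers stand for weaker inhibition and lower numbers for stronger inhibition), a value of > 5000 nM, which is a limit of this assay rather than a number.
Compound 2 `CCOc1cc(C(Nc2ccc3c(N)nccc3c2)C(=O)NS(=O)(=O)c2cccc(CO)c2)ccc1OC(C)C` gives in this assay > 5000 nM, again a limit.
Compound 3 `CCOc1cc(C(Nc2ccc3c(N)nccc3c2)C(=O)NS(=O)(=O)c2cccc(S(N)(=O)=O)c2)ccc1OC(C)C` gives in this assay > 5000 nM, also a limit.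

All three measured compounds therefore sit at the same limit (the limit of > 5000 nM in this assay, at which 3 of the 3 values shown sit), and compound 3 stands nowhere more precisely than that: only a limit is known for it, and the two other values are limits as well. The steps among the measured compounds, from compound 1 to compound 2 a step that the two limits leave unreadable from compound 1 to compound 2, from compound 1 to compound 3 a step that the two limits leave unreadable from compound 1 to compound 3 and from compound 2 to compound 3 a step that the two limits leave unreadable from compound 2 to compound 3, are all unreadable in size for the same reason.

The unmeasured compound 4 `CCOc1cc(C(Nc2ccc3c(N)nccc3c2)C(=O)NS(=O)(=O)c2ccc(O)cc2)ccc1OC(C)C` differs from compound 3 in the group on the sulfonyl sulfur: 4-hydroxyphenyl in place of 3-sulfamoylphenyl on a sulfonyl sulfur. The two steps that change the same position, from compound 1 to compound 3 and from compound 2 to compound 3, bear on it, but neither has a readable size. No step beyond the scatter can be predicted in this assay, and the expected step is a step that the limit leaves unreadable from compound 3 to compound 4. Compound 4 is accordingly estimated at 8000 nM, within a range from 3000 nM to 30000 nM, most probably reported once more as a limit.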

Compound 4, inhibition constant: > 5000 nM
Compound 4: only a limit was reported; the forecaster's own chance of this, stated with the estimate: 80%; the middle value is on the limit's open side.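

In this assay compound 4 gives > 5000 nM and this is a limit. For the compounds shown here, no step from compound 1, compound 2 or compound 3 to compound 4 can be read, since all four compounds rest at the same limit: the limit of > 5000 nM in this assay, at which 4 of the 4 values shown sit.
The compounds shown leave open how strong any inhibition by these four compounds is, and whether changing the group on the sulfonyl sulfur alters it.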